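Pyrrolidine amide carrying a methyl-oxopiperazine in a carboxylesterase assay

The source may report more compounds than this note shows. Statements on the series, on what has been measured and on what is new or still open speak of the compounds shown alone.

Compound 1 `Cc1c[nH]c(C)c1C(=O)O` gives 100000 nM in an assay on cells for inhibition of Palmitoleoyl-protein carboxylesterase NOTUM variant C330S (Homo sapiens), read by fluorescence, with a stated time of 40 min; a higher number here means a weaker inhibitor, a lower number a stronger inhibitor. Compound 2 `Cc1ccccc1-n1c(C)cc(C(=O)O)c1C` gives 2200 nM in this assay. Compound 3 `CN(C)C(=O)C1CCN(c2ccc(Cl)c(C(F)(F)F)c2)C1` gives 1200 nM in this assay.

Going by the values given here, of the three numbers so far, compound 3 has the lowest. Its distance to compound 2 lies within the scatter of this assay, so the two cannot be ranked against each other; its distance to compound 1 lies well beyond the scatter, and compound 1 stands clearly apart from the other two.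

Compound 4 `CN1CCN(C(=O)C2CCN(c3ccc(Cl)c(C(F)(F)F)c3)C2)CC1=O` differs from compound 3 in one place: 4-methyl-3-oxopiperazin-1-yl in place of dimethylamino on a carbonyl carbon. Among the compounds with values here, no pair of measured compounds here shows what such a change does in this assay, so the expectation rests on compound 3 alone. A change of this kind at the amide end, away from the aryl-bearing ring, is expected to shift the number by no more than the scatter, with a slight lean toward a weaker inhibitor. Compound 4 is therefore estimated at 1600 nM, with a range of 450 nM to 6000 nM. The estimated step from compound 3 to compound 4 is a 1.3-fold higher number from compound 3 to compound 4 (0.12 log units; within the scatter).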

Compound 4, half-maximal inhibitory concentration: 3100 nM
The estimate for compound 4 lay 1.9-fold (0.29 log units) below the measured number; measured number inside the range.
By their numbers in this assay, from the lowest: compounds 3, 2 and 4 (each within the scatter of the next, the first and the last beyond it); then compound 1.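

Going by these compounds alone, compound 3 and compound 4 form the first pair that differ in one place, so the amide end can now be read directly. In this assay, exchanging dimethylamino for 4-methyl-3-oxopiperazin-1-yl on the carbonyl carbon gives a 2.6-fold higher number from compound 3 to compound 4 (0.41 log units; beyond the scatter), which shows that this position accepts a much larger group bearing a six-membered ring, at a modest cost in inhibition. Nothing available accounts for the size or direction of this step.

The compounds shown do not separate the contributions of the ring, its carbonyl and its methyl group to this step. As far as these compounds go, a piperazine without the ring carbonyl, a morpholine, or an unsubstituted pyrrolidine on the same carbonyl carbon would address that question, and whether any group here can give a lower number than dimethylamino remains open.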